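Imidazole to pyridine swap: expectation for compound 3

This account rests on a few compounds, and the source may have more. Where it says the series, first, only, none or still open, it means among the compounds named here.

Measured compounds:
compound 1 `O=C(Nc1cccc(Cl)c1)O/N=C(\C1CCCCC1)C(Cn1ccnc1)C1CCCCC1` — in an assay on isolated protein for displacement of a labelled ligand from metabotropic glutamate receptor 5 (Rattus norvegicus) (a higher number here means a weaker inhibitor, a lower number a stronger inhibitor), compound 1 gives 10.8 nM; 8.78 nM; 1000 nM (3 entries)
compound 2 `Cc1nccn1CC(/C(=N/OC(=O)Nc1cccc(Cl)c1)C1CCCCC1)C1CCCCC1` — in this assay compound 2 gives > 1000 nM

Compound 2 stands only at a limit of this assay; the value recorded for compound 2 is a limit of the assay and not a number (the limit of > 1000 nM in this assay, at which 1 of the 2 values shown sits). Compound 1 carries several entries, and those entries do not agree with one another (the several entries of compound 1 in this assay, 10.8 nM; 8.78 nM; 1000 nM (3 entries)). Going by the values given here, no step between measured compounds is available, so the pair can only be read as two results side by side.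

Compound 3 `O=C(Nc1cccc(Cl)c1)O/N=C(\C1CCCCC1)C(Cc1ccncc1)C1CCCCC1` differs from compound 2 by pyridin-4-yl in place of 2-methyl-1H-imidazol-1-yl on a saturated chain carbon, two bonds along the chain from a carbon with a double bond to nitrogen and a saturated ring carbon. Among the compounds with values here, no measured step supports this change, and the starting point is itself a limit, so the direction can only be guessed. An expectation toward a stronger binder is taken, set as an at least 3.3-fold lower number from compound 2 to compound 3 (0.52 log units; beyond the scatter), with wide uncertainty in both directions. Compound 3 is estimated at 300 nM in this assay, with a range from 20 nM to 3000 nM, and a real chance that only a limit is reported again.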

Compound 3, inhibition constant: 117 nM
Compound 3: middle estimate off by 2.6-fold (0.41 log units), on the high side, and the stated range covers the measured number.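

Position notes: in this assay, replacing 2-methyl-1H-imidazol-1-yl with pyridin-4-yl on this saturated chain carbon gives an at least 8.5-fold lower number from compound 2 to compound 3 (0.93 log units; beyond the scatter), so this position accepts a six-membered aromatic ring with a single hetero atom and the series keeps a measurable binding value there. Going by these compounds, compound 2 gives > 1000 nM, which is a limit and not a number, so the step fixes only the direction and a minimum size, and its true size remains unknown. Compound 3 gives 117 nM, which supplies a firm numerical reference for this position, something the earlier pair did not offer in the form of one agreed value and one number.

Where pyridin-4-yl ranks against the unsubstituted imidazol-1-yl of compound 1 stays unsettled, since that reference does not reduce to a single value: the several entries of compound 1 in this assay, 10.8 nM; 8.78 nM; 1000 nM (3 entries). Also open, on these data alone, is whether the ring nitrogen of pyridin-4-yl is needed at all, a question that a phenyl group at this place would address.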